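Swapping a phenyl for tert-butyl on the triazole

The compounds below may be only part of what the source reports. "The series", "measured", "known", "first", "only" and "open" are said of these compounds alone.

Compound 1 `CN(CCNCc1cn(-c2ccccc2)nn1)CCNc1ccnc2cc(Cl)ccc12`: 26000 nM
Compound 2 `CN(CCNCc1cn(-c2cccc(Cl)c2)nn1)CCNc1ccnc2cc(Cl)ccc12`: 9400 nM

In a functional assay on HCC827 cells (Homo sapiens) for antiproliferative activity, read by sulforhodamine B assay, with a stated time of 72 h (a higher number here means a weaker inhibitor, a lower number a stronger inhibitor), compound 1 gives the highest of the two numbers, and its nearest neighbour is compound 2, a step of a 2.8-fold lower number from compound 1 to compound 2 (0.44 log units; beyond the scatter). Compound 3 `CN(CCNCc1cn(C(C)(C)C)nn1)CCNc1ccnc2cc(Cl)ccc12` differs from compound 1 by tert-butyl in place of phenyl on an aromatic nitrogen. Going by the values given here, no measured step changes the group on that aromatic nitrogen itself; the only step known touches the phenyl with a chloro, so it offers little guidance here. Compound 3 is therefore expected near compound 1, with a step of a 1.2-fold higher number from compound 1 to compound 3 (0.06 log units; within the scatter), and an estimated 30000 nM spanning 9000 nM to 90000 nM.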

Compound 3, half-maximal inhibitory concentration: 56000 nM
Compound 3: the middle estimate sits 1.9-fold (0.27 log units) below what was measured; low and high end bracket the measured number.
By their numbers in this assay, from the lowest: compound 2; then compound 1; then compound 3.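

In this assay the group on the aromatic nitrogen itself proves open to change with a measurable result: tert-butyl in place of phenyl gives (a 2.2-fold higher number from compound 1 to compound 3 (0.33 log units; beyond the scatter)), and tert-butyl in place of 3-chlorophenyl gives the larger step (a 6.0-fold higher number from compound 2 to compound 3 (0.78 log units; beyond the scatter)). Among these three compounds, the two with an aromatic ring at this position give the lower numbers and the ring-free tert-butyl the highest. No measured evidence accounts for this difference. On these data alone, whether it follows from losing the aromatic ring stays open: cyclohexyl at this position would separate ring from aromaticity, and methyl would test a much shorter group.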